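Series notes: ring substituent swap on the shared core

The source may hold more compounds than are shown below. What is called first, only, known or untested is meant among the compounds shown, and "the series" means these compounds.

compound 1 `CC(C(=O)NCc1ccc(C(F)(F)F)nc1N1CC=CCC1)c1ccc(NS(C)(=O)=O)c(F)c1` — 0.3 nM
compound 2 `COC1CCN(c2nc(C(F)(F)F)ccc2CNC(=O)C(C)c2ccc(NS(C)(=O)=O)c(F)c2)CC1` — 2.4 nM
compound 3 `CC(=O)OC1CCN(c2nc(C(F)(F)F)ccc2CNC(=O)C(C)c2ccc(NS(C)(=O)=O)c(F)c2)CC1` — 4 nM

In a functional assay on CHO-K1 cells for antagonist activity at transient receptor potential cation channel subfamily V member 1 (Homo sapiens), read by FLIPR (on this read-out higher numbers stand for weaker inhibition and lower numbers for stronger inhibition), compound 3 stands highest of the three numbers; the step of a 1.7-fold higher number from compound 2 to compound 3 (0.22 log units; within the scatter) is small, whereas a 13-fold higher number from compound 1 to compound 3 (1.12 log units; beyond the scatter) is large.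

Compound 4 `CC(C(=O)NCc1ccc(C(F)(F)F)nc1N1CCN(C)CC1)c1ccc(NS(C)(=O)=O)c(F)c1` differs from compound 3 by 4-methylpiperazin-1-yl in place of 4-acetoxypiperidin-1-yl on an aromatic carbon. Among the compounds with values here, the steps that bear on this change alter the same group on the same aromatic carbon: an 8.0-fold higher number from compound 1 to compound 2 (0.90 log units; beyond the scatter) and a 13-fold higher number from compound 1 to compound 3 (1.12 log units; beyond the scatter) both move to a larger group and both weaken inhibition, while a 1.7-fold higher number from compound 2 to compound 3 (0.22 log units; within the scatter) stays within the scatter. Within the data shown here, the entering group is smaller than those of compounds 2 and 3, though no measured step covers a 4-methylpiperazin-1-yl group. Expected in this assay is a modest lowering of the number, a 2.0-fold lower number from compound 3 to compound 4 (0.30 log units; within the scatter). For compound 4 the estimate is 2 nM, with a range of 0.4 nM to 10 nM.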

Compound 4, inhibition constant: 146 nM
Beside the measured number, compound 4's estimate is 73-fold (1.86 log units) below it; measured number above the stated range.
By their numbers in this assay, from the lowest: compound 1; then compounds 2 and 3 (each within the scatter of the next); then compound 4.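

In this assay, heavy-atom count does not order the groups at this position next to the ring nitrogen: the smaller 4-methylpiperazin-1-yl gives a 37-fold higher number from compound 3 to compound 4 (1.56 log units; beyond the scatter) against 4-acetoxypiperidin-1-yl and a 61-fold higher number from compound 2 to compound 4 (1.78 log units; beyond the scatter) against 4-methoxypiperidin-1-yl. The whole span now reaches a 490-fold higher number from compound 1 to compound 4 (2.69 log units; beyond the scatter) and shows that this position can separate six-membered rings far more widely than compounds 1, 2 and 3 did.

Open, from the compounds shown here alone, is whether the loss follows the second ring nitrogen or its methyl; morpholin-4-yl or 4-acetylpiperazin-1-yl would help separate the two. The data shown offer no measurement that accounts for this loss.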